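Swapping morpholine for a pyrrolidinylpiperidine on the sulfonyl sulfur

The compounds below may be only part of what the source reports. "The series", "measured", "known", "first", "only" and "open" are said of these compounds alone.

In a functional assay on A2780 cells (Homo sapiens) for cytotoxicity, read by sulforhodamine B assay, with a stated time of 72 h (a higher number here means a weaker inhibitor, a lower number a stronger inhibitor), compound 1 `CC(C)n1cc(S(=O)(=O)c2ccc(CNC(=O)N3Cc4ccncc4C3)cc2)cn1` gives 11 nM, compound 2 `CN1CCC(S(=O)(=O)c2ccc(CNC(=O)N3Cc4ccncc4C3)cc2)CC1` gives 99 nM and compound 3 `O=C(NCc1ccc(S(=O)(=O)N2CCOCC2)cc1)N1Cc2ccncc2C1` gives 68 nM. Compound 3 thus stands level with one relative, a 1.5-fold lower number from compound 2 to compound 3 (0.16 log units; within the scatter), and on the weaker side of the other, a 6.2-fold higher number from compound 1 to compound 3 (0.79 log units; beyond the scatter). The next change leads to compound 4 `O=C(NCc1ccc(S(=O)(=O)N2CCC(N3CCCC3)CC2)cc1)N1Cc2ccncc2C1`: 4-(pyrrolidin-1-yl)piperidin-1-yl in place of morpholin-4-yl on a sulfonyl sulfur. Among the measured compounds shown here, earlier swaps on this sulfonyl sulfur reached a 9.0-fold higher number from compound 1 to compound 2 (0.95 log units; beyond the scatter), but that step and the one to compound 3 both leave the aromatic 1-isopropyl-1H-pyrazol-4-yl. The swap between non-aromatic groups stayed within the scatter, and the entering group is also non-aromatic. The expected step is therefore small, a 1.1-fold lower number from compound 3 to compound 4 (0.05 log units; within the scatter), with no clear direction in this assay. For compound 4 the estimate is 60 nM, with an expected range of 18 nM to 200 nM.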

Compound 4, half-maximal inhibitory concentration: 5.6 nM
Estimate against measurement, compound 4: 11-fold (1.03 log units) above, and the stated range ends above it.
By their numbers in this assay, from the lowest: compounds 4 and 1 (each within the scatter of the next); then compounds 3 and 2 (each within the scatter of the next).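

On the sulfonyl sulfur, non-aromatic groups prove far from interchangeable in this assay: although compound 2 and compound 3 stood level, the 4-(pyrrolidin-1-yl)piperidin-1-yl group gives a 12-fold lower number from compound 3 to compound 4 (1.08 log units; beyond the scatter) and an 18-fold lower number from compound 2 to compound 4 (1.25 log units; beyond the scatter). The aromatic 1-isopropyl-1H-pyrazol-4-yl is also not required for a number this low, as a 2.0-fold lower number from compound 1 to compound 4 (0.29 log units; within the scatter) leaves the two compounds level. No evidence shown here accounts for the large steps. Open, from the compounds shown here alone, is whether a dimethylamino group in place of the pyrrolidin-1-yl ring would keep them, and whether a 4-methylpiperazin-1-yl group on the sulfonyl sulfur would do the same.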